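Swapping an Amide for a Sulfonamide on the Outer Ring

The source may report more compounds than this note shows. Statements on the series, on what has been measured and on what is new or still open speak of the compounds shown alone.

Compound 1 `CSc1ccc(Nc2ncnc3sc(Nc4c(Cl)cccc4Cl)nc23)cc1` carries a methylsulfanyl group on its outer benzene ring. In a functional assay on HEK293 cells for antagonist activity at transient receptor potential cation channel subfamily V member 1 (Homo sapiens), read by calcium flux (on this read-out lower numbers stand for stronger inhibition and higher numbers for weaker inhibition), compound 1 gives 96 nM. Compound 2 `O=C(c1ccc(Nc2ncnc3sc(Nc4c(Cl)cccc4Cl)nc23)cc1)N1CCCC1` differs from it only in that group. In this assay compound 2 reaches > 5000 nM, which is a limit of the assay and not a measured number. The exchange brought an at least 52-fold higher number from compound 1 to compound 2 (1.71 log units; beyond the scatter), and compound 2 therefore stands at the limit of > 5000 nM in this assay, at which 1 of the 2 values shown sits, the weak end of what has been measured. Compound 3 `NS(=O)(=O)c1ccc(Nc2ncnc3sc(Nc4c(Cl)cccc4Cl)nc23)cc1` continues from compound 2 with one change: sulfamoyl in place of (pyrrolidin-1-yl)carbonyl on an aromatic carbon. For the measured compounds named here, only the single measured step bears on this change, and it shows that replacing the methylsulfanyl group at this position came at a large cost. The step of an at least 1.6-fold lower number from compound 2 to compound 3 (0.22 log units; that floor lies within the scatter) is expected to be modest, with compound 3 staying weak. Compound 3 is estimated to give 3000 nM, within a range from 400 nM to 20000 nM.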

Compound 3, half-maximal inhibitory concentration: > 5000 nM
Compound 3 was reported as a limit; the forecaster's own chance of this, stated with the estimate: 45%; at least 1.6-fold (0.22 log units) between middle value and limit.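

In this assay, sulfamoyl proves no better a replacement for methylsulfanyl on the aromatic carbon than the amide was, with the exchange bringing an at least 52-fold higher number from compound 1 to compound 3 (1.71 log units; beyond the scatter). The two incoming groups differ plainly, one with a five-membered ring and no hydrogen-bond donor and the other with no ring and a hydrogen-bond donor, yet neither keeps the activity that methylsulfanyl gives in these three compounds. Compound 2 and compound 3 are each known only as a limit of the assay, so the step between them cannot be read, and the limit now holds most of the series: the limit of > 5000 nM in this assay, at which 2 of the 3 values shown sit.

From the compounds shown here alone, it remains open whether a methoxy group, a methyl group or a longer sulfur chain such as ethylsulfanyl would keep the activity of compound 1. Going by these compounds, how weak compound 2 and compound 3 truly are also stays unknown.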